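Hydroxy for Amino on a Fused Core

The source may hold more compounds than are shown below. What is called first, only, known or untested is meant among the compounds shown, and "the series" means these compounds.

Measured compounds:
- compound 1, `CCOC(=O)CC[C@H](NC(=O)c1ccc(CNc2ccc3nc(N)nc(N)c3c2C)cc1)C(=O)OCC`, 7.7
- compound 2, `Nc1nc(O)c2cc(Sc3ccc(Cl)c(Cl)c3)ccc2n1`, 6.92

Of the compounds shown here, two have been tested in an assay for inhibition of Dihydrofolate reductase (Homo sapiens); on this read-out higher numbers stand for higher potency (the scale is a negative logarithm) and lower numbers for lower potency. Compound 1 stands highest of the two numbers, with 7.7. The nearest number belongs to compound 2, which gives 6.92, a gap that lies beyond the usual scatter. Going by the values given here, compound 2 carries a hydroxy on its core where compound 1 carries an amino, but the two compounds differ in several other places as well, so no single step between them can be read.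

The unmeasured compound 3, `CCOC(=O)CC[C@H](NC(=O)c1ccc(CNc2ccc3nc(N)nc(O)c3c2C)cc1)C(=O)OCC`, differs from compound 1 in one place only: hydroxy in place of amino on an aromatic carbon. Among the compounds with values here, no measured pair shows this exact change on its own. Still, the lower number of compound 2, 6.92, hints that a hydroxy at this place goes with a weaker result. Compound 3 is therefore expected to fall below compound 1 by a step beyond the scatter, a number 1.70 log units lower from compound 1 to compound 3 (beyond the scatter). The estimate for compound 3 is 6, within a range from 5 to 7.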

Compound 3, logarithm of the reciprocal of the active concentration, log(1/C): 5.57
Beside the measured number, compound 3's estimate is 0.43 log units above it; the measured number falls inside the stated range.
By their numbers in this assay, from the lowest: compound 3; then compound 2; then compound 1.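

Going by these compounds alone, replacing amino with hydroxy on the shared core, with everything else held the same, gives a number 2.13 log units lower from compound 1 to compound 3 (beyond the scatter) in this assay, so this change can now be read on its own, which the earlier compounds, differing in several places, did not allow. The two groups match in heavy-atom count, hydrogen-bond donors, hydrogen-bond acceptors and net charge, so a large step arises here from a change that these counts do not register, with one nitrogen giving way to one oxygen on the aromatic carbon next to the ring nitrogen. Nothing among the data shown explains why the number falls so far at this position.

As far as these compounds go, it remains open whether other groups at this place, such as methylamino or methoxy, would stay close to compound 1 or fall as far as compound 3. From the compounds shown here alone, this step also comes from a single pair, so whether the same exchange costs as much on compounds with a different side chain is still unknown.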